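Replacing a Nitro Group with Acetyl: What to Expect

A few compounds are considered here, and "the series" means these few. Any claim that something is new, unique, unknown or untested is made for them only; others in the source may bear on it.

Of the compounds shown here, three that share one core have been tested in a functional assay on OVCAR-3 cells (Homo sapiens) for inhibition, read by MTT assay, with a stated time of 24 h; a lower number here means a stronger inhibitor, a higher number a weaker inhibitor. Compound 1 `CCc1ccc(/C=C/[C@@H]2CCCCN2)cc1` carries an ethyl group on its aromatic ring and gives 5.07 ug/mL. Compound 2 `FC(F)(F)c1ccc(/C=C/[C@@H]2CCCCN2)cc1` carries a trifluoromethyl group in its place and gives 0.99 ug/mL. Compound 3 `O=[N+]([O-])c1ccc(/C=C/[C@@H]2CCCCN2)cc1` carries a nitro group at the same place and gives 1.02 ug/mL. Among these three numbers compound 3 holds the second highest: the step of a 1.0-fold higher number from compound 2 to compound 3 (0.01 log units; within the scatter) lies within the scatter, whereas the step of a 5.0-fold lower number from compound 1 to compound 3 (0.70 log units; beyond the scatter) lies beyond it.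

Compound 4 `CC(=O)c1ccc(/C=C/[C@@H]2CCCCN2)cc1` is the next member: acetyl in place of nitro on an aromatic carbon, on an aromatic carbon of a six-membered aromatic ring of carbon only, para to a group of 8 heavy atoms. The measured steps that bear on this change are those that swap one group for another at this aromatic carbon: a 5.1-fold lower number from compound 1 to compound 2 (0.71 log units; beyond the scatter), a 5.0-fold lower number from compound 1 to compound 3 (0.70 log units; beyond the scatter) and a 1.0-fold higher number from compound 2 to compound 3 (0.01 log units; within the scatter). Among the measured compounds shown here, none of them involves an acetyl group, so no step shows directly what acetyl does here. Two different replacements of ethyl gave the same modest drop, and the two replacing groups agree with each other; whether acetyl behaves like them cannot be read from these data. Compound 4 is therefore expected to land near compound 3, with an expected step of a 2.0-fold higher number from compound 3 to compound 4 (0.29 log units; within the scatter) that stays within the scatter. The estimate for compound 4 in this assay is 2 ug/mL, in the range 0.8 ug/mL to 5 ug/mL.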

Compound 4, half-maximal inhibitory concentration: 2.18 ug/mL
Compound 4: middle estimate off by 1.1-fold (0.04 log units), on the low side, and the stated range covers the measured number.
By their numbers in this assay, from the lowest: compounds 2 and 3 (each within the scatter of the next); then compound 4; then compound 1.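

In this assay, this aromatic carbon now shows more than the two levels seen earlier: acetyl does not match nitro, with a 2.1-fold higher number from compound 3 to compound 4 (0.33 log units; beyond the scatter), and it does not match trifluoromethyl, with a 2.2-fold higher number from compound 2 to compound 4 (0.34 log units; beyond the scatter). It also stays clearly apart from ethyl, with a 2.3-fold lower number from compound 1 to compound 4 (0.37 log units; beyond the scatter), so swapping nitro for acetyl gives back part of the gain over ethyl but not all of it, and the new group sits at a third, middle level. All three steps are modest, and nothing measured explains why acetyl falls where it does, so this order of groups stands as an observation only.

The compounds shown leave open where groups of other kinds would fall at this carbon, such as an amine, a carboxylic acid or a nitrile, and whether a longer chain on the carbonyl would stay close to acetyl. They also leave open whether the same order of the four groups would hold on a different core.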